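Trifluoromethyl Position Swap in a Pentafluorosulfanyl Anilide Series

The compounds below may be only part of what the source reports. "The series", "measured", "known", "first", "only" and "open" are said of these compounds alone.

compound 1 `CC(O)(CSc1cccc(C(F)(F)F)c1)C(=O)Nc1ccc(S(F)(F)(F)(F)F)cc1`: 18800 nM
compound 2 `CC(O)(CSc1ccccc1C(F)(F)F)C(=O)Nc1ccc(S(F)(F)(F)(F)F)cc1`: 21000 nM
compound 3 `CC(O)(CSc1cccc(C(F)(F)F)c1)C(=O)Nc1cccc(S(F)(F)(F)(F)F)c1`: 20200 nM

Three compounds were measured in a functional assay on VCaP cells (Homo sapiens) for antiproliferative activity, read by propidium iodide staining, with a stated time of 96 h; on this read-out higher numbers stand for weaker inhibition and lower numbers for stronger inhibition. In this assay compound 1 gives 18800 nM, compound 2 gives 21000 nM and compound 3 gives 20200 nM; all three values lie within the scatter of one another, so no ordering among them can be claimed.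

Compound 2 differs from compound 1 by one change, (2-(trifluoromethyl)phenyl in place of 3-(trifluoromethyl)phenyl on a sulfur), and this change made a 1.1-fold higher number from compound 1 to compound 2 (0.05 log units; within the scatter). The cores of compound 3 and compound 1 differ in a way that is not broken down here; their values show only that the two sit within the scatter.

Compound 4 `CC(O)(CSc1ccccc1C(F)(F)F)C(=O)Nc1cccc(S(F)(F)(F)(F)F)c1` has not yet been measured. It differs from compound 3 by 2-(trifluoromethyl)phenyl in place of 3-(trifluoromethyl)phenyl on a sulfur, which is the same change as that from compound 1 to compound 2, made at the same place. Because the earlier step was a 1.1-fold higher number from compound 1 to compound 2 (0.05 log units; within the scatter), the step from compound 3 to compound 4 is expected to be similarly small, a 1.1-fold higher number from compound 3 to compound 4 (0.04 log units; within the scatter). Compound 4 is therefore estimated at 22000 nM, with a range from 11000 nM to 44000 nM.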

Compound 4, half-maximal inhibitory concentration: 21000 nM
Compound 4: the middle estimate sits 1.0-fold (0.02 log units) above what was measured, and the stated range covers the measured number.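

In this assay, 2-(trifluoromethyl)phenyl in place of 3-(trifluoromethyl)phenyl on a sulfur gave a 1.0-fold higher number from compound 3 to compound 4 (0.02 log units; within the scatter). Set beside the earlier case, the change behaved alike on the two cores: the same change on two cores in this assay, a 1.1-fold higher number (0.05 log units; within the scatter) from compound 1 to compound 2 and a 1.0-fold higher number (0.02 log units; within the scatter) from compound 3 to compound 4, 1.1-fold (0.03 log units) apart, within the scatter of two such steps

On these two cores, then, the swap carried over as a step too small to read, and the core of compound 3 gave no sign of a different response from the core of compound 1. This does not show that the change would stay this small on any other core, and since neither step rises above the scatter, it gives no measure of how a real effect of the swap would transfer.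

The compounds shown leave open how the number would respond to a different group on the phenyl ring, such as a nitrile or a methoxy group, in place of trifluoromethyl. They also leave open what a sulfone in place of the sulfur, or a chlorine in place of the pentafluorosulfanyl group, would do.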